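Notes on the series: from compound 2 to compound 3

The source may hold more compounds than are shown below. What is called first, only, known or untested is meant among the compounds shown, and "the series" means these compounds.

Measured in an in vitro ADME assay on microsomes from liver (Mus musculus) for pharmacokinetics, read by LC-MS, with a stated time of 10 min, tested at 1 uM; a lower number here means slower removal, a higher number faster removal of the compound:
- compound 1 `CN1C[C@H](C(=O)Nc2ccccc2)[C@@H](c2ccc(/C=C/C(=O)Nc3ccccc3N)cc2)C1`: 67 mL/min/kg
- compound 2 `CN1C[C@H](C(=O)Nc2ccc(Br)cc2)[C@@H](c2ccc(/C=C/C(=O)Nc3ccccc3N)cc2)C1`: 16 mL/min/kg

Of the two, compound 2 has the lower number, at 16 mL/min/kg. Compound 3 `COc1cccc(NC(=O)[C@H]2CN(C)C[C@@H]2c2ccc(/C=C/C(=O)Nc3ccccc3N)cc2)c1` carries 3-methoxyphenyl in place of 4-bromophenyl on an amide-type nitrogen. Within the data shown here, only one measured step bears on this change: a 4.2-fold lower number from compound 1 to compound 2 (0.62 log units; beyond the scatter), bromo in place of hydrogen on an aromatic carbon, beyond the scatter. Compound 3 has no bromo, but no methoxy change has been measured, so a partial return towards compound 1 is expected. The expected step is a 2.5-fold higher number from compound 2 to compound 3 (0.40 log units; beyond the scatter), a higher number. For compound 3 the estimate is 40 mL/min/kg, with an expected range of 18 mL/min/kg to 85 mL/min/kg.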

Compound 3, clearance: 65 mL/min/kg
Beside the measured number, compound 3's estimate is 1.6-fold (0.21 log units) below it; low and high end bracket the measured number.
By their numbers in this assay, from the lowest: compound 2; then compounds 3 and 1 (each within the scatter of the next).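

In this assay, 3-methoxyphenyl in place of 4-bromophenyl on the amide-type nitrogen gives a 4.1-fold higher number from compound 2 to compound 3 (0.61 log units; beyond the scatter), while adding methoxy gives a 1.0-fold lower number from compound 1 to compound 3 (0.01 log units; within the scatter), within the scatter. Among these three compounds, only the 4-bromophenyl of compound 2 stands apart, so a substituent on this ring does not by itself give a lower number. Nothing at hand explains this difference.

Group and ring location change together between compound 2 and compound 3, so their contributions cannot be separated. Going by these compounds, whether chloro or an amine on this ring would fall with compound 2 or with compounds 1 and 3 remains open.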